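The source may hold more compounds than are shown below. What is called first, only, known or untested is meant among the compounds shown, and "the series" means these compounds.

Three analogues sharing one core have been measured in a functional assay on NCI-H1975 cells (Homo sapiens) for inhibition, read by sulforhodamine B assay, tested at 10 uM; a higher number here means more inhibition at the concentration tested (going by the name of the read-out), a lower number less inhibition. Compound 1 `CN(C)c1ccc(C2CC(c3ccc(-n4cncn4)cc3)=NN2C(=O)c2ccc(C(F)(F)F)cc2)cc1` gives 11.5%. Compound 2 `C=C(C)C(=O)N1N=C(c2ccc(-n3ccnc3)cc2)CC1c1ccc(N(C)C)cc1` gives -3.7%, and compound 3 `COC(=O)CC(=O)N1N=C(c2ccc(-n3ccnc3)cc2)CC1c1ccc(N(C)C)cc1` gives -0.1%. Among the measured compounds shown here, compound 3 therefore stands second highest of the three numbers: its nearest neighbour is compound 2, and the only measured step, a number 3.6 percentage points higher from compound 2 to compound 3 (within the scatter), lies within the scatter; its furthest neighbour is compound 1, whose number is higher by a margin beyond the scatter.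

Compound 4 `CN(C)c1ccc(C2CC(c3ccc(-n4ccnc4)cc3)=NN2C(=O)c2ccc(C(F)(F)F)cc2)cc1` has not yet been measured in this assay. It differs from compound 3 in one place: 4-(trifluoromethyl)phenyl in place of (methoxycarbonyl)methyl on a carbonyl carbon. For the measured compounds named here, no measured step covers this exact exchange. Going by the values given here, the one step on hand, from compound 2 to compound 3, swapped two small groups on the carbonyl carbon and moved the number by an amount within the scatter, so it says little about bringing in an aromatic ring. Compound 1 carries the same 4-(trifluoromethyl)phenyl on its carbonyl carbon, and its number is the highest of the three, so the entering group is at least compatible with a modestly higher reading.

On that basis compound 4 is expected to give about 10%, within a range of -2% to 22%. The step this estimate implies, a number 10.1 percentage points higher from compound 3 to compound 4 (beyond the scatter), is expected to be small and upward, near the edge of the scatter.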

Compound 4, a percentage reported as inhibition, at one concentration (the size of the read-out at that concentration, not a potency): 15.9%
For compound 4 the middle estimate is 5.9 percentage points below the measured one, and the stated range covers the measured number.
By their numbers in this assay, from the lowest: compounds 2 and 3 (each within the scatter of the next); then compounds 1 and 4 (each within the scatter of the next).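

With the imidazole-bearing core held fixed in this assay, compound 4 shows that the group on this carbonyl carbon can shift the reading: 4-(trifluoromethyl)phenyl in place of (methoxycarbonyl)methyl gives a number 16 percentage points higher from compound 3 to compound 4 (beyond the scatter) and in place of 1-methylethenyl gives a number 19.6 percentage points higher from compound 2 to compound 4 (beyond the scatter) on the same core. The earlier exchange between the two groups without a ring stayed within the scatter, and compound 1 differed from those compounds in two places, so neither showed this change on its own. Among the compounds shown here, the new comparison with compound 1 also isolates the azole for the first time: 1H-imidazol-1-yl in place of 1H-1,2,4-triazol-1-yl gives a number 4.4 percentage points higher from compound 1 to compound 4 (within the scatter), so with this carbonyl substituent the compounds show no separable difference between the two azoles.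

The compounds shown leave open whether the six-membered aromatic ring or its trifluoromethyl accompanies the step, a question that a plain phenyl or a phenyl bearing an amine on this carbonyl carbon would address. Nothing available explains the step itself.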